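Taking the allylsulfanyl group off compound 3

This account rests on a few compounds, and the source may have more. Where it says the series, first, only, none or still open, it means among the compounds named here.

Measured so far in a functional assay on MGC-803 cells (Homo sapiens) for inhibition, read by MTT assay, with a stated time of 72 h; on this read-out higher numbers stand for weaker inhibition and lower numbers for stronger inhibition:

- compound 1 `Cc1cc(Nc2cc(-c3ccccc3)[nH]n2)n2nc(SCC(=O)c3ccccc3)nc2n1` gives 2580 nM
- compound 2 `Cc1cc(Nc2cc(-c3ccccc3)[nH]n2)n2nc(SCCCc3ccccc3)nc2n1` gives 6510 nM
- compound 3 `C=CCSc1nc2nc(C)cc(Nc3cc(-c4ccccc4)[nH]n3)n2n1` gives 17200 nM

Compound 3, at 17200 nM, has the highest number of the three and so the weakest inhibition. Compound 4 `Cc1cc(Nc2cc(-c3ccccc3)[nH]n2)n2ncnc2n1` has not yet been measured. It carries hydrogen in place of allylsulfanyl on an aromatic carbon and so loses the sulfur-bound chain altogether.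

Three modest steps bear on this change, all on that chain: a 2.5-fold higher number from compound 1 to compound 2 (0.40 log units; beyond the scatter), a 6.7-fold higher number from compound 1 to compound 3 (0.82 log units; beyond the scatter) and a 2.6-fold higher number from compound 2 to compound 3 (0.42 log units; beyond the scatter). Among the measured compounds shown here, putting vinyl in place of benzoyl or phenethyl raised the number both times, and no compound here goes against that. For the measured compounds named here, none of the measured compounds lacks the chain, however, so the step to hydrogen is an extrapolation. A further modest rise in this assay, toward weaker inhibition, is therefore expected. Going by the values given here, the expected change is a 2.3-fold higher number from compound 3 to compound 4 (0.37 log units; beyond the scatter) and no larger step is assumed. Compound 4 is estimated at 40000 nM, with an expected range of 15000 nM to 110000 nM.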

Compound 4, half-maximal inhibitory concentration: 21700 nM
For compound 4 the middle estimate is 1.8-fold (0.27 log units) above the measured one; the measured number falls inside the stated range.
By their numbers in this assay, from the lowest: compound 1; then compound 2; then compounds 3 and 4 (each within the scatter of the next).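

In this assay, taking the allylsulfanyl group off leaves the number within the scatter (a 1.3-fold higher number from compound 3 to compound 4 (0.10 log units; within the scatter)), so at this aromatic carbon that chain cannot be told from hydrogen. The two chains that carry a phenyl ring do stand apart from hydrogen, both beyond the scatter (a 3.3-fold higher number from compound 2 to compound 4 (0.52 log units; beyond the scatter); an 8.4-fold higher number from compound 1 to compound 4 (0.92 log units; beyond the scatter)), so among these compounds only the (3-phenylpropyl)sulfanyl and (benzoylmethyl)sulfanyl groups give a lower number than hydrogen, and sulfur with an allyl chain does not. No measurement at hand explains this difference between the chains.

As far as these compounds go, it remains open whether the sulfur is needed at all, since an amine or a methoxy group at this carbon could show that. Also open, from the compounds shown here alone, is whether a benzylsulfanyl group, or a phenyl ring directly on this carbon, would give similarly low numbers.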